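The source may hold more compounds than are shown below. What is called first, only, known or untested is meant among the compounds shown, and "the series" means these compounds.

Two ribonucleosides have been measured so far. Among the measured compounds shown here, in a functional assay on K562 cells (Homo sapiens), read by MTT assay, with a stated time of 72 h (a lower number here means a stronger inhibitor, a higher number a weaker inhibitor), compound 2 `CNc1ncnc2c1c(-c1ccco1)cn2[C@@H]1O[C@H](CO)[C@@H](O)[C@H]1O` gives 220 nM as the only actual number. For compound 1 `COc1ncnc2c1c(-c1ccccc1)cn2[C@@H]1O[C@H](CO)[C@@H](O)[C@H]1O` the reading > 20000 nM is only a limit. Compound 3 `CNc1ncnc2c1c(-c1cc3ccccc3o1)cn2[C@@H]1O[C@H](CO)[C@@H](O)[C@H]1O` differs from compound 2 by 1-benzofuran-2-yl in place of furan-2-yl on an aromatic carbon and so has 1-benzofuran-2-yl in place of furan-2-yl on an aromatic carbon. For the measured compounds named here, no measured pair isolates this change, so the expectation in this assay is a judgement: a large step toward weaker inhibition. The estimated step is an 18-fold higher number from compound 2 to compound 3 (1.26 log units; beyond the scatter) in that direction. Compound 3 is estimated at 4000 nM with 600 nM to 20000 nM as its expected range.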

Compound 3, half-maximal inhibitory concentration: > 20000 nM
Compound 3 gave a limit, no number; the forecaster's own chance of this, stated with the estimate: 30%; middle value at least 5.0-fold (0.69 log units) away from the limit.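

In this assay, among the compounds shown here, 1-benzofuran-2-yl in place of furan-2-yl on this aromatic carbon gives an at least 90-fold higher number from compound 2 to compound 3 (1.95 log units; beyond the scatter), the first comparison here that isolates a single change. It shows that this position does not accept every group containing a five-membered aromatic ring with one oxygen: adding the six-membered aromatic ring of carbon only costs nearly all measurable inhibition. For compound 3 the reading is a limit, not a number, so the step could be larger: the limit of > 20000 nM in this assay, at which 2 of the 3 values shown sit.

As far as these compounds go, how a methyl group or thiophen-2-yl would read at this carbon remains open. So does whether an amine on the 1-benzofuran-2-yl ring would change the result.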